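Three compounds at the assay limit, a fourth to come

A few compounds are considered here, and "the series" means these few. Any claim that something is new, unique, unknown or untested is made for them only; others in the source may bear on it.

In an ADME assay on PC-3 cells (Homo sapiens) for cytotoxicity, read by CCK-8 assay, with a stated time of 6 days (on this read-out lower numbers stand for stronger inhibition and higher numbers for weaker inhibition), three compounds sharing one core have been examined, and all three stand at the same limit rather than at a number. Compound 1 `CC(=O)c1ccc(C(=O)N[C@@H](C)Cn2ccc(-c3ccc(C#N)c(Cl)c3)n2)cc1` gives > 30000 nM, a limit of the assay. Compound 2 `COc1ccc(C(=O)N[C@@H](C)Cn2ccc(-c3ccc(C#N)c(Cl)c3)n2)cc1` gives > 30000 nM, again a limit. Compound 3 `C[C@@H](Cn1ccc(-c2ccc(C#N)c(Cl)c2)n1)NC(=O)C1CC(=O)C1` gives > 30000 nM, also a limit. Because (the limit of > 30000 nM in this assay, at which 3 of the 3 values shown sit), none of the steps among them can be read: the step that the two limits leave unreadable from compound 1 to compound 2, the step that the two limits leave unreadable from compound 1 to compound 3 and the step that the two limits leave unreadable from compound 2 to compound 3 are all hidden by the two limits, so compound 3 stands only at the limit, level with the other two as far as the data reach.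

Compound 4 `Cc1ccnc(N[C@@H](C)Cn2ccc(-c3ccc(C#N)c(Cl)c3)n2)n1` differs from compound 3 in one place: 4-methylpyrimidin-2-yl in place of (3-oxocyclobutyl)carbonyl on an amine nitrogen. Within the data shown here, the steps that bear on this change, from compound 1 and compound 2 to compound 3, are both unreadable, so no measured step gives its size or direction.

On that basis compound 4 is expected to remain at the limit, with an estimate of 30000 nM, ranging from 10000 nM to 100000 nM. The expected step is a number no higher from compound 3 to compound 4 (the limit leaves the size open), which is no step beyond the scatter.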

Compound 4, half-maximal inhibitory concentration: > 30000 nM
Compound 4 ended at the assay's limit (the forecaster's own chance of this, stated with the estimate: 75%); the middle value sits exactly at the limit.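

No new step can be read from compound 3 to compound 4, since compound 4 stands, like every other compound shown, only at a limit: the limit of > 30000 nM in this assay, at which 4 of the 4 values shown sit.

The compounds shown leave open how strongly any of them acts in this assay, and whether any change on the shared core shifts the read-out.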